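Swapping a Tetrazole for Piperidine on the Aryl Carbon

A few compounds are considered here, and "the series" means these few. Any claim that something is new, unique, unknown or untested is made for them only; others in the source may bear on it.

Measured so far, in a functional assay on HEK293 cells for agonist activity at Bombesin receptor subtype-3 (Homo sapiens), read by luminescence and calcium flux, with a stated time of 10 min; a lower number here means that less compound is needed, a higher number that more compound is needed for the effect:
Compound 1, `CCC(C)(C)Cc1c[nH]c(CCc2ccc(-c3ccncc3)cc2)n1`, gives 95 nM.
Compound 2, `CCC(C)(C)Cc1c[nH]c(CCc2ccc(-c3cccnc3)cc2)n1`, gives 98 nM.
Compound 3, `CCC(C)(C)Cc1c[nH]c(CCc2ccc(-n3ncnn3)cc2)n1`, gives 89 nM.

The three compounds share one core and differ only in the group on an aromatic carbon of the carbon-only six-membered ring. The steps between them are all small: a 1.0-fold higher number from compound 1 to compound 2 (0.01 log units; within the scatter), a 1.1-fold lower number from compound 1 to compound 3 (0.03 log units; within the scatter) and a 1.1-fold lower number from compound 2 to compound 3 (0.04 log units; within the scatter). Compound 3 has the lowest number of the three, but its distance to compound 1 and to compound 2 lies within the scatter, so the three compounds cannot be ranked.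

Compound 4, `CCC(C)(C)Cc1c[nH]c(CCc2ccc(N3CCCCC3)cc2)n1`, has not been measured in this assay. The change from compound 3 is piperidin-1-yl in place of 2H-tetrazol-2-yl on an aromatic carbon. Within the data shown here, no measured step covers a non-aromatic ring at this place; the three measured steps only show that exchanging one aromatic group for another there left the number within the scatter. On that basis compound 4 is expected to stay near compound 3, with a wider band of uncertainty because the entering group is of a different kind, corresponding to an estimated 1.3-fold higher number from compound 3 to compound 4 (0.13 log units; within the scatter). The estimated value for compound 4 in this assay is 120 nM, ranging from 30 nM to 500 nM.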

Compound 4, half-maximal effective concentration: 108 nM
Estimate against measurement, compound 4: 1.1-fold (0.05 log units) above, within the range that was stated.
By their numbers in this assay, from the lowest: compounds 3, 1, 2 and 4 (each within the scatter of the next).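

In this assay, among these compounds, a non-aromatic ring now stands on this aromatic carbon, para to a large group, where the earlier compounds carried only aromatic rings. The exchange for piperidin-1-yl gives a 1.2-fold higher number from compound 3 to compound 4 (0.08 log units; within the scatter) and a 1.1-fold higher number from compound 2 to compound 4 (0.04 log units; within the scatter) and also a 1.1-fold higher number from compound 1 to compound 4 (0.06 log units; within the scatter) and so, whichever aromatic group leaves, the number stays within the scatter. The four compounds therefore show that the number in this assay can stay the same when an aromatic ring gives way to a non-aromatic one and when, as counted for 2H-tetrazol-2-yl and piperidin-1-yl, 4 hydrogen-bond acceptors give way to 1, and no measurement available here says why these groups read alike.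

Going by these compounds, all four groups are whole rings joined directly to the aromatic carbon, so it remains open whether an open chain such as n-butyl, a carboxylic acid or a primary amine at the same place would also leave the number unchanged. A plain hydrogen there, with no ring at all, would show whether the group at this place matters to the number in the first place.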